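Removing one chloro from the dichlorobenzyl arm of compound 1

This account rests on a few compounds, and the source may have more. Where it says the series, first, only, none or still open, it means among the compounds named here.

Compound 1 `O=C1c2ccccc2N(Cc2ccc(Cl)c(Cl)c2)S(=O)(=O)N1Cc1ccccc1` is measured in a functional assay on CCRF-CEM cells (Homo sapiens) for inhibition (a lower number here means that less compound is tolerated, a higher number that more compound is tolerated), and gives 16400 nM, the lowest number of the two measured compounds. Compound 2 `O=C1c2ccccc2N(Cc2ccccc2)S(=O)(=O)N1COCc1ccccc1` gives in this assay 100000 nM, a higher number that lies beyond the scatter of compound 1. Compound 3 `O=C1c2ccccc2N(Cc2ccc(Cl)cc2)S(=O)(=O)N1Cc1ccccc1` differs from compound 1 by hydrogen in place of chloro on an aromatic carbon, that is, 3,4-dichlorobenzyl to 4-chlorobenzyl. Among the compounds with values here, no measured pair shows this change. A small step toward a higher number is expected, a 1.5-fold higher number from compound 1 to compound 3 (0.18 log units; within the scatter), probably within the scatter or only just beyond it. Compound 3 is estimated at 25000 nM, with a range from 10000 nM to 70000 nM.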

Compound 3, half-maximal cytotoxic concentration: 19700 nM
The estimate for compound 3 lay 1.3-fold (0.10 log units) above the measured number; the measured number falls inside the stated range.
By their numbers in this assay, from the lowest: compounds 1 and 3 (each within the scatter of the next); then compound 2.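

Going from 3,4-dichlorobenzyl to 4-chlorobenzyl gives a 1.2-fold higher number from compound 1 to compound 3 (0.08 log units; within the scatter) in this assay, so this aromatic carbon, ortho to a chloro group, takes hydrogen in place of chloro without a step beyond the scatter. This single-place pair thus shows that, with the other arm kept as benzyl, the loss of this one chlorine leaves the reading unresolved from that of the dichloro compound. No supporting data bear on why this is so.

Still open, on these data alone, is whether the remaining chloro can also give way to hydrogen with the benzyl arm unchanged. Also open, as far as these compounds go, is how an amine or a carboxylic acid would read on this aromatic carbon.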